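Working notes: pentafluoroethyl in place of a sulfur-fluorine group

This account rests on a few compounds, and the source may have more. Where it says the series, first, only, none or still open, it means among the compounds named here.

Measured compounds:
compound 1 `CC(O)(COc1cccc(S(F)(F)(F)(F)F)c1)C(=O)Nc1ccc(C(F)(F)F)cc1` — 21000 nM
compound 2 `CC(O)(COc1ccc(S(F)(F)(F)(F)F)cc1)C(=O)Nc1cc(C(F)(F)F)cc(C(F)(F)F)c1` — 6500 nM
compound 3 `CC(O)(COc1cccc(C(F)(F)C(F)(F)F)c1)C(=O)Nc1ccc(C(F)(F)F)cc1` — 7600 nM

All three were run in a functional assay on DU-145 cells (Homo sapiens) for antiproliferative activity, read by propidium iodide staining, with a stated time of 96 h; a lower number here means a stronger inhibitor, a higher number a weaker inhibitor. Compound 2 and compound 3 lie within the scatter of each other; compound 1 stands apart from both. Compound 3 differs from compound 1 by a group of 7 heavy atoms (2 carbon, 5 fluorine; no ring) in place of a group of 6 heavy atoms (5 fluorine, 1 sulfur; no ring), on an aromatic carbon, and this made a 2.8-fold lower number from compound 1 to compound 3 (0.44 log units; beyond the scatter).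

Compound 4 `CC(O)(COc1ccc(C(F)(F)C(F)(F)F)cc1)C(=O)Nc1cc(C(F)(F)F)cc(C(F)(F)F)c1` is not yet measured. It differs from compound 2 by a group of 7 heavy atoms (2 carbon, 5 fluorine; no ring) in place of a group of 6 heavy atoms (5 fluorine, 1 sulfur; no ring), on an aromatic carbon. This is the same kind of change as that from compound 1 to compound 3, not the same: in compound 1 the group sits meta to a large group, in compound 2 para to a large group. The difference between the two cores, those of compound 1 and compound 2, is not broken down here.

For the measured compounds named here, for compound 4 a step of a 2.2-fold lower number from compound 2 to compound 4 (0.35 log units; beyond the scatter) is expected in this assay, resting on a 2.8-fold lower number from compound 1 to compound 3 (0.44 log units; beyond the scatter); the place differs and only one measured example exists, so a somewhat smaller step is assumed. Compound 4 is estimated at 2900 nM, between 1200 nM and 6500 nM.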

Compound 4, half-maximal inhibitory concentration: 6800 nM
Estimate against measurement, compound 4: 2.3-fold (0.37 log units) below; measured number outside the range, above it.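

In this assay, 1,1,2,2,2-pentafluoroethyl in place of the sulfur-fluorine group gives a 1.0-fold higher number from compound 2 to compound 4 (0.02 log units; within the scatter), so the lower number seen on the core of compound 1 does not carry over to the core of compound 2. The step therefore depends on the core in these two pairs: the same change on two cores in this assay, a 2.8-fold lower number (0.44 log units; beyond the scatter) from compound 1 to compound 3 and a 1.0-fold higher number (0.02 log units; within the scatter) from compound 2 to compound 4, 2.9-fold (0.46 log units) apart, beyond the scatter of two such steps
Which difference between the cores matters remains unresolved: the place of the group and the trifluoromethyl substitution on the amide side change together, and two pairs set no rule for the series.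

Still open, going by these compounds, is how either core behaves with a nitrile, a chlorine or a longer fluorinated chain in that place. Also open, on these data alone, is whether the group's place or the amide-side substitution governs the step.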